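Swapping the fluorinated benzyl arm on compound 2

A few compounds are considered here, and "the series" means these few. Any claim that something is new, unique, unknown or untested is made for them only; others in the source may bear on it.

Compound 1 `CCN(CC)c1ccc2cc(C(=O)c3ccc(N4CCN(C(=O)CN5CCNCC5)CC4)cc3)oc2c1`: > 100000 nM
Compound 2 `CCN(CC)c1ccc2cc(C(=O)c3ccc(N4CCN(C(=O)CN5CCN(Cc6ccc(F)c(F)c6)CC5)CC4)cc3)oc2c1`: 10200 nM

Compound 1 `CCN(CC)c1ccc2cc(C(=O)c3ccc(N4CCN(C(=O)CN5CCNCC5)CC4)cc3)oc2c1` carries a free amine nitrogen in its outer ring. In an ADME assay on L02 cells (Homo sapiens) for cytotoxicity, read by MTT assay, with a stated time of 48 h (a lower number here means a stronger inhibitor, a higher number a weaker inhibitor), compound 1 gives > 100000 nM, which is a limit of the assay rather than a number. Compound 2 `CCN(CC)c1ccc2cc(C(=O)c3ccc(N4CCN(C(=O)CN5CCN(Cc6ccc(F)c(F)c6)CC5)CC4)cc3)oc2c1` adds a 3,4-difluorobenzyl group on that nitrogen, and in this assay compound 2 gives 10200 nM. This is the only number shown; the step of an at least 9.8-fold lower number from compound 1 to compound 2 (0.99 log units; beyond the scatter) is at least modest, and its size is bounded only by the limit of > 100000 nM in this assay, at which 1 of the 2 values shown sits.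

Compound 3 `CCN(CC)c1ccc2cc(C(=O)c3ccc(N4CCN(C(=O)CN5CCN(Cc6ccc(C(F)(F)F)cc6)CC5)CC4)cc3)oc2c1` differs from compound 2 in one place: 4-(trifluoromethyl)phenyl in place of 3,4-difluorophenyl on a saturated chain carbon bound to an amine nitrogen in a ring. Going by the values given here, no measured step swaps one substituted benzyl for another, so the single step from compound 1 to compound 2 speaks only to the benzyl group being present, not to which fluorine pattern it carries. Both groups are of similar size, so the expected change in this assay is none beyond the scatter, and compound 3 is estimated at 8500 nM, between 3000 nM and 25000 nM, a step of a 1.2-fold lower number from compound 2 to compound 3 (0.08 log units; within the scatter).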

Compound 3, half-maximal inhibitory concentration: 6540 nM
Compound 3: the middle estimate sits 1.3-fold (0.11 log units) above what was measured; the range from low to high includes it.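

In this assay, exchanging one fluorinated arm for the other gives a 1.6-fold lower number from compound 2 to compound 3 (0.19 log units; within the scatter), so the two arms cannot be told apart here, even though 4-(trifluoromethyl)phenyl has more heavy atoms than 3,4-difluorophenyl. A second benzyl group on the same amine nitrogen also separates clearly from the free amine, with an at least 15-fold lower number from compound 1 to compound 3 (1.18 log units; beyond the scatter), so the shift seen earlier is not tied to a single fluorine pattern and holds for both benzyl groups shown. The true size of that shift stays unknown, since compound 1 sits at a limit of the assay and not at a number: the limit of > 100000 nM in this assay, at which 1 of the 3 values shown sits.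

On these data alone, whether fluorine plays any part in this remains open, and a plain benzyl group without fluorine, or a methyl group, on that nitrogen would separate the effect of fluorine from the effect of simply having a group there. Also open, as far as these compounds go, is how an arm ending in a carboxylic acid, or a longer chain between the ring nitrogen and the phenyl ring, would read in this assay.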